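Trimming the Methoxy Group: From Compound 3 to Compound 4

The source may hold more compounds than are shown below. What is called first, only, known or untested is meant among the compounds shown, and "the series" means these compounds.

Within the data shown here, compound 3 `COCCN(Cc1cccs1)C(=O)COc1ccc(C)cc1` gives 400 nM in an assay on HEK293 cells for agonist activity at transient receptor potential cation channel subfamily M member 8 (Homo sapiens), read by fluorescence and calcium flux, with a stated time of 15 min (on this read-out lower numbers stand for an effect already at smaller amounts and higher numbers for an effect only at larger amounts of compound), the second highest of the three numbers so far: compound 1 `CCN(Cc1ccc(C)s1)C(=O)COc1ccc(C)cc1` gives 178 nM, and compound 2 `Cc1ccc(OCC(=O)N(Cc2cccs2)CC(C)C)cc1` gives 900 nM. Compound 4 `CCN(Cc1cccs1)C(=O)COc1ccc(C)cc1` differs from compound 3 in one place: hydrogen in place of methoxy on a saturated chain carbon, two bonds along the chain from an amide-type nitrogen. Among the measured compounds shown here, the one measured step touching this part of the molecule is a 2.3-fold lower number from compound 2 to compound 3 (0.35 log units; beyond the scatter), a modest gain from a methoxy-bearing chain. Compound 1, which carries ethyl in the same position but differs elsewhere, gives 178 nM, so a short chain is evidently tolerated. A small lowering, or none beyond the scatter, is therefore expected, a 1.5-fold lower number from compound 3 to compound 4 (0.19 log units; within the scatter). Compound 4 is estimated at 260 nM, within 100 nM to 650 nM.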

Compound 4, half-maximal effective concentration: 8 nM
Compound 4: the middle estimate sits 33-fold (1.51 log units) above what was measured; the measured number lies below the stated range.
By their numbers in this assay, from the lowest: compound 4; then compound 1; then compound 3; then compound 2.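

Hydrogen in place of methoxy on this chain matters far more than the earlier compounds showed: in this assay it gives a 50-fold lower number from compound 3 to compound 4 (1.70 log units; beyond the scatter) and leaves a plain ethyl chain on the amide-type nitrogen. Methyl in place of isopropyl on the saturated chain carbon gives a 110-fold lower number from compound 2 to compound 4 (2.05 log units; beyond the scatter) and so places this ethyl chain well ahead of the branched one. With the ethyl chain kept, hydrogen in place of methyl on an aromatic carbon gives a 22-fold lower number from compound 1 to compound 4 (1.35 log units; beyond the scatter) and shows that this small methyl also weighs heavily.

Going by these compounds, whether a propyl chain or an amine in this place would keep so low a number stays open. No evidence is available to account for the size of these steps.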